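This account rests on a few compounds, and the source may have more. Where it says the series, first, only, none or still open, it means among the compounds named here.

Working notes on the urea series on the shared core of compound 1 `COc1cc(Nc2ncnc3c(NC(=O)Nc4ccc(C)cc4C)cccc23)cc(OC)c1`. Among the compounds with values here, in a functional assay on RT-112 cells (Homo sapiens) for antiproliferative activity, read by MTT assay, with a stated time of 72 h (on this read-out lower numbers stand for stronger inhibition of growth and higher numbers for weaker inhibition of growth), compound 1 gives 1290 nM, the highest of the three numbers measured so far. Compound 2 `COc1cc(Nc2ncnc3c(NC(=O)Nc4ccccc4Cl)cccc23)cc(OC)c1` gives 356 nM in this assay, and compound 3 `COc1cc(Nc2ncnc3c(NC(=O)Nc4ccc(C(F)(F)F)cc4Cl)cccc23)cc(OC)c1` gives 1080 nM. The steps among them are modest: a 3.6-fold lower number from compound 1 to compound 2 (0.56 log units; beyond the scatter), while a 1.2-fold lower number from compound 1 to compound 3 (0.08 log units; within the scatter), and a 3.0-fold higher number from compound 2 to compound 3 (0.48 log units; beyond the scatter).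

Compound 4 `COc1cc(Nc2ncnc3c(NC(=O)Nc4cccc(C(F)(F)F)c4F)cccc23)cc(OC)c1` has not been measured in this assay. It differs from compound 1 in one place: 2-fluoro-3-(trifluoromethyl)phenyl in place of 2,4-dimethylphenyl on an amide-type nitrogen.

Two of the measured steps bear on this change. Exchanging the 2,4-dimethylphenyl for a halogenated phenyl lowered the number in the step from compound 1 to compound 2, whereas adding a trifluoromethyl on the aromatic carbon raised it again in the step from compound 2 to compound 3. Compound 4 carries both a fluorine and a trifluoromethyl on its phenyl, so the two pulls are expected to partly cancel, leaving a step in the favourable direction of roughly the size seen between compound 1 and compound 3, or a little more. For compound 4 the expected step is a 1.7-fold lower number from compound 1 to compound 4 (0.24 log units; within the scatter), and the estimated value is 750 nM, within a range of 250 nM to 2200 nM.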

Compound 4, concentration for 50% growth inhibition: 471 nM
Beside the measured number, compound 4's estimate is 1.6-fold (0.20 log units) above it; measured number inside the range.
By their numbers in this assay, from the lowest: compounds 2 and 4 (each within the scatter of the next); then compounds 3 and 1 (each within the scatter of the next).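

In this assay, the 2-fluoro-3-(trifluoromethyl)phenyl group on the amide-type nitrogen gives a clear gain over the 2,4-dimethylphenyl group (a 2.7-fold lower number from compound 1 to compound 4 (0.44 log units; beyond the scatter)) and also over the 2-chloro-4-(trifluoromethyl)phenyl group (a 2.3-fold lower number from compound 3 to compound 4 (0.36 log units; beyond the scatter)), so a trifluoromethyl on this phenyl does not by itself go with the higher numbers seen for compound 3. Against the 2-chlorophenyl group the change gives a 1.3-fold higher number from compound 2 to compound 4 (0.12 log units; within the scatter), which leaves compound 2 and compound 4 level as a pair, each beyond the scatter from compound 1 and from compound 3. No measurement at hand accounts for these differences between the phenyl groups.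

The compounds shown leave open how much of the gain belongs to the fluorine and how much to the trifluoromethyl, since the two groups in compound 3 and compound 4 differ in both the halogen and the place of the trifluoromethyl, and neither substituent appears alone with the other held fixed. Also open, as far as these compounds go, is how this position answers a phenyl carrying a methoxy, a nitrile or an aminomethyl group.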